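Chloro in place of methyl on compound 1

The source may hold more compounds than are shown below. What is called first, only, known or untested is meant among the compounds shown, and "the series" means these compounds.

Going by the values given here, compound 1 `CCOc1ccc(F)cc1C(C)NC(=O)N(C)S(=O)(=O)c1ccc(C)cc1` gives 7800 nM in a functional assay on thoracic aorta (Rattus norvegicus, strain Wistar), with a stated time of 15 min (a lower number here means that less compound is needed, a higher number that more compound is needed for the effect), and this is the only numerical value so far. Compound 2 `COc1ccc(Br)cc1C(C)NC(=O)NS(=O)(=O)c1ccc(C)cc1` gives > 300000 nM in this assay, which is a limit of the assay and not a number. Among the compounds with values here, no step between measured compounds is available to show how a single change moves the half-maximal effective concentration.

The next compound is compound 3 `CCOc1ccc(F)cc1C(C)NC(=O)N(C)S(=O)(=O)c1ccc(Cl)cc1`, which keeps the core of compound 1 and changes one group: chloro in place of methyl on an aromatic carbon. This places chloro in place of methyl on an aromatic carbon, para to a large group, and so turns 4-methylphenyl into 4-chlorophenyl.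

Within the data shown here, no measured pair tests this change, so neither direction is favoured in this assay, and no shift beyond the scatter is expected. Among the measured compounds shown here, the only numerical reference is compound 1 at 7800 nM, so the estimate stays close to that value. The estimated change is a 1.1-fold lower number from compound 1 to compound 3 (0.05 log units; within the scatter). Compound 3 is expected at 7000 nM, with an estimated range of 2500 nM to 22000 nM.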

Compound 3, half-maximal effective concentration: 24500 nM
For compound 3 the middle estimate is 3.5-fold (0.54 log units) below the measured one, and the stated range ends below it.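

Going by these compounds alone, on the shared core of compound 1, the group in this position is not neutral in this assay: chloro in place of methyl gives a 3.1-fold higher number from compound 1 to compound 3 (0.50 log units; beyond the scatter), the first single-place step and one that lies beyond the scatter. With everything else held as in compound 1, 4-methylphenyl therefore needs less compound for the effect than 4-chlorophenyl, although this rests on one pair and does not establish a pattern for other cores or other groups. Nothing shown gives a measured property that accounts for this step.

As far as these compounds go, only methyl and chloro have been compared at this position, so it remains open how a methoxy group, an amine, a carboxylic acid or a longer chain would compare with them there. From the compounds shown here alone, compound 2 differs from compound 1 in more than one place, so the contribution of each of those differences remains open. Compound 2 gives > 300000 nM, which is a limit of the assay and not a number.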